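The source may report more compounds than this note shows. Statements on the series, on what has been measured and on what is new or still open speak of the compounds shown alone.

Measured so far:
compound 1, `O=C1N/C(=N\Cc2ccc(C(F)(F)F)cc2)S/C1=C1/CCNC(=O)c2[nH]ccc21`: > 100000 nM
compound 2, `O=C1N/C(=N\Cc2cccc(Cl)c2)S/C1=C1/CCNC(=O)c2[nH]ccc21`: 34700 nM

In a functional assay on SK-MEL-28 cells (Homo sapiens) for inhibition, read by MTT assay, with a stated time of 48 h (on this read-out lower numbers stand for stronger inhibition and higher numbers for weaker inhibition), compound 1 gives only a limit, > 100000 nM, and not a number. That is the limit of > 100000 nM in this assay, at which 1 of the 2 values shown sits. Compound 2 reaches a measured value in this assay of 34700 nM. Going by the values given here, of the two, compound 1 is the one without a number, sitting at the limit. Compound 3, `CC(C)(C)c1ccc(C/N=C2\NC(=O)/C(=C3\CCNC(=O)c4[nH]ccc43)S2)cc1`, is not yet measured. It differs from compound 1 in one place: tert-butyl in place of trifluoromethyl on an aromatic carbon. Among the compounds with values here, no step between measured compounds is available, so the expected size of this change rests on the structural difference alone. The step from compound 1 to compound 3 is expected to be small, an at least 1.4-fold lower number from compound 1 to compound 3 (0.15 log units; that floor lies within the scatter), not clearly beyond the scatter, with a fair chance that only a limit is reported again. Compound 3 is therefore estimated at 70000 nM, between 15000 nM and 300000 nM.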

Compound 3, half-maximal inhibitory concentration: 23500 nM
Compound 3: the middle estimate sits 3.0-fold (0.47 log units) above what was measured, and the stated range covers the measured number.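

On an aromatic carbon para to a large group, tert-butyl in place of trifluoromethyl gives, in this assay, an at least 4.2-fold lower number from compound 1 to compound 3 (0.62 log units; beyond the scatter). The exchange keeps the heavy-atom count and adds no ring, hydrogen-bond donor, hydrogen-bond acceptor or net charge, yet the step is beyond the scatter, so the read-out responds to the group at this position. The step is only a floor because compound 1 carries a limit and not a number: the limit of > 100000 nM in this assay, at which 1 of the 3 values shown sits.

The compounds shown do not tell whether an amine, a carboxylic acid or a methoxy group at this position would move the number in the same direction as tert-butyl. They also leave open whether a longer chain here would give a lower or a higher number than compound 3 gives, 23500 nM.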